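Phenyl for thiophene on a shared core

This account rests on a few compounds, and the source may have more. Where it says the series, first, only, none or still open, it means among the compounds named here.

In a functional assay on Ehrlich cells (Mus musculus) for cytotoxicity, tested at 10 ug/mL (on this read-out lower numbers stand for a weaker effect and higher numbers for a stronger effect at the one concentration tested), compound 1 `COc1cc(N2C(N)=C(C#N)C(c3ccc([N+](=O)[O-])cc3)C3=C2CC(C)(C)CC3=O)cc(OC)c1OC` gives 10%. Compound 2 `COc1ccc(C2C(C#N)=C(N)N(c3cc(OC)c(OC)c(OC)c3)C3=C2C(=O)CC(C)(C)C3)cc1` gives 0% in this assay. Compound 3 `COc1cc(N2C(N)=C(C#N)C(c3cccs3)C3=C2CC(C)(C)CC3=O)cc(OC)c1OC` gives 5% in this assay. Among these three numbers compound 3 stands second highest, with compound 1 nearest and compound 2 furthest, and both gaps lie within the scatter. The steps between the measured compounds agree: a number 10 percentage points lower from compound 1 to compound 2 (within the scatter), a number 5 percentage points lower from compound 1 to compound 3 (within the scatter) and a number 5 percentage points higher from compound 2 to compound 3 (within the scatter) are all within the scatter. Compound 4 `COc1cc(N2C(N)=C(C#N)C(c3ccccc3)C3=C2CC(C)(C)CC3=O)cc(OC)c1OC` has not yet been measured; its difference from compound 3 is phenyl in place of thiophen-2-yl on a saturated ring carbon. The two measured steps that exchange the group on the saturated ring carbon, namely a number 5 percentage points lower from compound 1 to compound 3 (within the scatter) and a number 5 percentage points higher from compound 2 to compound 3 (within the scatter), both stayed within the scatter, so no step beyond the scatter is expected for this exchange either. The expected step is no change at the digits printed from compound 3 to compound 4 (within the scatter). Compound 4 is therefore expected to give 5% in this assay, with a range from 0% to 15%.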

Compound 4, a percentage reported as activity, at one concentration (the size of the read-out at that concentration, not a potency): 0%
Beside the measured number, compound 4's estimate is 5 percentage points above it; measured number inside the range.
By their numbers in this assay, from the lowest: compounds 2, 4, 3 and 1 (each within the scatter of the next).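

In this assay, replacing thiophen-2-yl with phenyl gives a number 5 percentage points lower from compound 3 to compound 4 (within the scatter) on this saturated ring carbon, so a six-membered carbon ring and a five-membered ring with sulfur cannot be told apart here. The unsubstituted phenyl also isolates the group on that ring: hydrogen in place of methoxy gives no change at the digits printed from compound 2 to compound 4 (within the scatter) while hydrogen in place of nitro gives a number 10 percentage points lower from compound 1 to compound 4 (within the scatter), which means that neither group has an effect that can be separated from the scatter. No evidence is available to explain these results.

Every compound shown carries an aromatic ring at this position, so the effect of a cyclohexyl group, a longer alkyl chain or a phenyl ring bearing a carboxylic acid remains open. On these data alone, with only one concentration tested, how these compounds behave at higher concentrations is also open.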